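The source may hold more compounds than are shown below. What is called first, only, known or untested is meant among the compounds shown, and "the series" means these compounds.

Compound 2 `CCOC(=O)c1cnn(CC(O)CC)c1NC(=O)NCc1ccccc1` carries a benzyl group on the urea nitrogen of the shared core. In a functional assay on cells (Neutrophil, Homo sapiens) for inhibition, with a stated time of 10 min (on this read-out higher numbers stand for weaker inhibition and lower numbers for stronger inhibition), compound 2 gives > 10 nM, which is a limit of the assay rather than a number. Compound 1 `CCOC(=O)c1cnn(CC(O)CC)c1NC(=O)NC(C)C` gives > 10 nM in this assay, also a limit. Compound 3 `CCOC(=O)c1cnn(CC(O)CC)c1NC(=O)Nc1cccc(F)c1` gives 0.19 nM; the steps of an at least 52-fold lower number from compound 1 to compound 3 (1.72 log units; beyond the scatter) and an at least 52-fold lower number from compound 2 to compound 3 (1.72 log units; beyond the scatter) are both large, and the step that the two limits leave unreadable from compound 1 to compound 2 cannot be sized, since both values sit at the limit of > 10 nM in this assay, at which 2 of the 3 values shown sit.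

Compound 4 `CCOC(=O)c1cnn(C)c1NC(=O)NCc1ccccc1` differs from compound 2 only at the chain on the aromatic nitrogen: hydrogen in place of 1-hydroxypropyl on a saturated chain carbon bound to an aromatic nitrogen. Among the measured compounds shown here, none of the measured steps alters this position, so they give no direct guide. Compound 4 is therefore expected to stay near compound 2, a step that the limit leaves unreadable from compound 2 to compound 4, with an estimate of 30 nM and a range from 5 nM to 200 nM.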

Compound 4, half-maximal inhibitory concentration: 18 nM
Compound 4: middle estimate off by 1.7-fold (0.22 log units), on the high side, and the stated range covers the measured number.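

Among the compounds shown here, no step can be sized from compound 2 to compound 4, since compound 2 gives only a limit: the limit of > 10 nM in this assay, at which 2 of the 4 values shown sit. The compounds shown leave open how far replacing 1-hydroxypropyl with hydrogen shifts the number in this assay.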